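A few compounds are considered here, and "the series" means these few. Any claim that something is new, unique, unknown or untested is made for them only; others in the source may bear on it.

Working notes on the series, read in a functional assay on MDA-MB-231 cells (Homo sapiens) for antiproliferative activity, read by MTT assay, with a stated time of 48 h; a lower number here means a stronger inhibitor, a higher number a weaker inhibitor: compound 1 `C=CS(=O)(=O)N1CCN(c2ncnc3sc(-c4ccc(OC)cc4)cc23)CC1` gives 29900 nM, compound 2 `C=CS(=O)(=O)N1CCN(c2ncnc3sc(-c4ccc(C#N)cc4)cc23)CC1` gives 8050 nM, and compound 3 `C=CS(=O)(=O)N1CCN(c2ncnc3sc(-c4ccc(OC)nc4)cc23)CC1` gives 9270 nM. Compound 3 therefore sits within the scatter of compound 2, and both lie clearly under compound 1. Compound 4 `C=CS(=O)(=O)N1CCN(c2ncnc3sc(-c4cccs4)cc23)CC1` carries thiophen-2-yl in place of 6-methoxypyridin-3-yl on an aromatic carbon. Three measured swaps at this place bear on it: a 3.7-fold lower number from compound 1 to compound 2 (0.57 log units; beyond the scatter), a 3.2-fold lower number from compound 1 to compound 3 (0.51 log units; beyond the scatter) and a 1.2-fold higher number from compound 2 to compound 3 (0.06 log units; within the scatter). These steps are modest or smaller, and none introduces a five-membered ring, so no step beyond the scatter is expected, with no firm direction. The expected step is a 1.1-fold higher number from compound 3 to compound 4 (0.03 log units; within the scatter). For compound 4 the estimated value in this assay is 10000 nM, with an expected range of 4000 nM to 25000 nM.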

Compound 4, half-maximal inhibitory concentration: 34100 nM
Beside the measured number, compound 4's estimate is 3.4-fold (0.53 log units) below it, outside the stated range (above it).
By their numbers in this assay, from the lowest: compounds 2 and 3 (each within the scatter of the next); then compounds 1 and 4 (each within the scatter of the next).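

In this assay, thiophen-2-yl at this position, on an aromatic carbon next to the ring sulfur, gives up the level of the two better six-membered groups: a 3.7-fold higher number from compound 3 to compound 4 (0.57 log units; beyond the scatter) and a 4.2-fold higher number from compound 2 to compound 4 (0.63 log units; beyond the scatter). With a 1.1-fold higher number from compound 1 to compound 4 (0.06 log units; within the scatter), it cannot be told apart from 4-methoxyphenyl, so ring size alone does not sort the series, as the six-membered group of compound 1 reads with the five-membered one. No measurement available here accounts for these steps. Still open, as far as these compounds go, is whether a nitrile on the thiophen-2-yl ring would recover the level of compound 2, and how a carboxylic acid or an aminomethyl group would read at this position.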